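The source may report more compounds than this note shows. Statements on the series, on what has been measured and on what is new or still open speak of the compounds shown alone.

Measured compounds in an assay on isolated protein for agonist activity at Bile acid receptor (Homo sapiens), read by TR-FRET; on this read-out lower numbers stand for an effect already at smaller amounts and higher numbers for an effect only at larger amounts of compound:
compound 1 `CCn1c(-c2ccc(OCc3c(-c4c(Cl)cccc4Cl)noc3C(C)C)cc2)nc2ccc(C(=O)O)cc21` gives 19.3 nM
compound 2 `CCCn1c(-c2ccc(OCc3c(-c4c(Cl)cccc4Cl)noc3C(C)C)cc2)nc2ccc(C(=O)O)cc21` gives 96.4 nM
compound 3 `CCCC(CCC)n1c(-c2ccc(OCc3c(-c4c(Cl)cccc4Cl)noc3C(C)C)cc2)nc2ccc(C(=O)O)cc21` gives 30.3 nM

Compound 3 holds the second highest of the three numbers. Its nearest neighbour is compound 1, with a 1.6-fold higher number from compound 1 to compound 3 (0.20 log units; within the scatter), a step within the scatter; its furthest is compound 2, with a 3.2-fold lower number from compound 2 to compound 3 (0.50 log units; beyond the scatter). The remaining pair, compound 1 and compound 2, shows a 5.0-fold higher number from compound 1 to compound 2 (0.70 log units; beyond the scatter).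

Compound 4 `CC(C)c1onc(-c2c(Cl)cccc2Cl)c1COc1ccc(-c2nc3ccc(C(=O)O)cc3n2C(C)C)cc1` has not yet been measured. It differs from compound 3 by isopropyl in place of 1-propylbutyl on an aromatic nitrogen. Within the data shown here, two measured steps concern the group on this nitrogen: a 1.6-fold higher number from compound 1 to compound 3 (0.20 log units; within the scatter) was within the scatter, while a 3.2-fold lower number from compound 2 to compound 3 (0.50 log units; beyond the scatter) was a modest fall in the number. The group that enters in compound 4 is smaller than the one that leaves, as the counts above show; the step from compound 1 to compound 3 suggests such a change alters little, whereas the step from compound 2 to compound 3 hints that a smaller group on this nitrogen may bring a somewhat higher number. On balance compound 4 is expected to sit close to compound 3, with a 1.2-fold higher number from compound 3 to compound 4 (0.06 log units; within the scatter), which would not be beyond the scatter. The estimate for compound 4 in this assay is 35 nM, with a range from 12 nM to 100 nM.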

Compound 4, half-maximal effective concentration: 56.7 nM
Estimate against measurement, compound 4: 1.6-fold (0.21 log units) below, and the stated range covers the measured number.
By their numbers in this assay, from the lowest: compounds 1, 3, 4 and 2 (each within the scatter of the next, the first and the last beyond it).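

In this assay, isopropyl on this aromatic nitrogen cannot be told apart from either 1-propylbutyl (a 1.9-fold higher number from compound 3 to compound 4 (0.27 log units; within the scatter)) or propyl (a 1.7-fold lower number from compound 2 to compound 4 (0.23 log units; within the scatter)), so neither exchange can be read as a real difference. The only clear separation for isopropyl is from ethyl (a 2.9-fold higher number from compound 1 to compound 4 (0.47 log units; beyond the scatter)), a modest step beyond the scatter, which places ethyl apart from isopropyl as it already stood apart from propyl. The four groups therefore give no steady trend with size: 1-propylbutyl, the largest group, stays within the scatter of ethyl (a 1.6-fold higher number from compound 1 to compound 3 (0.20 log units; within the scatter)), whereas propyl and isopropyl, both smaller than 1-propylbutyl, do not both stay within the scatter of ethyl or follow any order of chain length.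

On these data alone, how a ring on this nitrogen, such as cyclopropyl or phenyl, or a chain carrying an amine or a hydroxyl group would read in this assay stays open. Nothing at hand accounts for why ethyl stands apart from propyl and isopropyl on this nitrogen.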